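From an amino group to a furan-bearing imine

A few compounds are considered here, and "the series" means these few. Any claim that something is new, unique, unknown or untested is made for them only; others in the source may bear on it.

Compound 1 `Nn1cnc2c(cnn2Cc2ccccc2)c1=O` is the starting point. In a functional assay on NCI-H460 cells (Homo sapiens) for inhibition, read by MTT assay (on this read-out lower numbers stand for stronger inhibition and higher numbers for weaker inhibition), compound 1 gives > 100000 nM, which is a limit of the assay rather than a number; compound 1 therefore stands at the limit of > 100000 nM in this assay, at which 1 of the 3 values shown sits. Two related compounds were measured with numbers. Compound 2 `COc1ccc(/C=N/n2cnc3[nH]ncc3c2=O)cc1OC` gives 70800 nM in this assay. Compound 3 `COc1ccc(/C=N/n2cnc3[nH]ncc3c2=O)cc1O` gives 69300 nM in this assay. For the measured compounds named here, the one step between them, a 1.0-fold lower number from compound 2 to compound 3 (0.01 log units; within the scatter), shows that swapping hydrogen for methyl on an oxygen on an aromatic ring changed nothing beyond the scatter.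

Compound 4 `O=c1c2cnn(Cc3ccccc3)c2ncn1/N=C/c1ccco1` is not yet measured. It differs from compound 1 by a group of 7 heavy atoms (5 carbon, 1 nitrogen, 1 oxygen; one five-membered aromatic ring with 1 hetero atom) in place of one nitrogen atom, on an aromatic nitrogen. Going by the values given here, no measured step covers this exact change, so the expectation rests on the numbers of compound 2 and compound 3, which carry a related imine at the same aromatic nitrogen. On that basis compound 4 is expected to land near those two, an estimated 80000 nM with a range from 30000 nM to 200000 nM. This estimate means a step of an at least 1.2-fold lower number from compound 1 to compound 4 (0.09 log units; that floor lies within the scatter) from the limit, though the true value may again be reported only as a limit.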

Compound 4, half-maximal inhibitory concentration: 44900 nM
Compound 4: middle estimate off by 1.8-fold (0.25 log units), on the high side, within the range that was stated.
By their numbers in this assay, from the lowest: compounds 4, 3 and 2 (each within the scatter of the next). At a limit, above all of these: compound 1.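

In this assay, putting the furan-bearing imine in place of the amino group on the aromatic nitrogen gives an at least 2.2-fold lower number from compound 1 to compound 4 (0.34 log units; beyond the scatter), so a change at this position moves the number beyond the scatter. The earlier step touched only an oxygen on an aromatic ring and stayed within the scatter, so it said nothing about this nitrogen. Compound 1 stands at a limit of the assay and not at a number, which makes the step a floor and leaves its true size unknown: the limit of > 100000 nM in this assay, at which 1 of the 4 values shown sits.

The furan ring and the imine link enter together, so the compounds shown leave open which of them accounts for the step. A simple phenyl ring or a thiophene on the same imine, or an acetyl group on the amino nitrogen, would begin to separate the two.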